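Swapping 4-methylphenyl for 2-fluorophenyl on a carbonyl carbon

The source may report more compounds than this note shows. Statements on the series, on what has been measured and on what is new or still open speak of the compounds shown alone.

Of the compounds shown here, three have been read in a functional assay on A549 cells (Homo sapiens) for antiproliferative activity, read by MTT assay, with a stated time of 24 h; on this read-out higher numbers stand for weaker inhibition and lower numbers for stronger inhibition. Within the data shown here, compound 1 `O=C(NNc1ccccc1F)c1cccc(NS(=O)(=O)c2cnc(O)nc2O)c1` gives 11100 nM, the only true number so far. Compound 2 `O=C(NNc1ccc(F)cc1)c1cccc(NS(=O)(=O)c2cnc(O)nc2O)c1` reports only a limit, > 20000 nM. Compound 3 `Cc1ccc(C(=O)NNC(=O)c2cccc(NS(=O)(=O)c3cnc(O)nc3O)c2)cc1` also reports only a limit, > 20000 nM. Compound 3 therefore stands at the limit of > 20000 nM in this assay, at which 2 of the 3 values shown sit, with no number of its own as a starting point.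

Compound 4 `O=C(NNC(=O)c1ccccc1F)c1cccc(NS(=O)(=O)c2cnc(O)nc2O)c1` is still unmeasured. It carries 2-fluorophenyl in place of 4-methylphenyl on a carbonyl carbon.

Among the measured compounds shown here, the steps that bear on this change are an at least 1.8-fold higher number from compound 1 to compound 2 (0.25 log units; that floor lies within the scatter) and an at least 1.8-fold higher number from compound 1 to compound 3 (0.25 log units; that floor lies within the scatter). Both were made on an amine nitrogen, not on a carbonyl carbon. Compound 1 also carries 2-fluorophenyl, but on an amine nitrogen, so its link to compound 4 is loose. The remaining step, a step that the two limits leave unreadable from compound 2 to compound 3, gives no size.

None of these steps supports a move beyond the scatter in this assay, and none is expected. The expected step is a number no higher from compound 3 to compound 4 (the limit leaves the size open). Compound 4 is estimated at 20000 nM, with an expected range of 10000 nM to 40000 nM. A further report as a limit is the likelier expected outcome.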

Compound 4, half-maximal inhibitory concentration: 10800 nM
For compound 4 the middle estimate is 1.9-fold (0.27 log units) above the measured one; the range from low to high includes it.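

In this assay, 2-fluorophenyl on the carbonyl carbon gives a true number where 4-methylphenyl gave only a limit of the assay, a change that reads as an at least 1.8-fold lower number from compound 3 to compound 4 (0.26 log units; that floor lies within the scatter) and the first firm sign that this position can respond. The comparison with the 4-fluorophenyl compound, which carries no carbonyl at this point, reads as an at least 1.8-fold lower number from compound 2 to compound 4 (0.26 log units; that floor lies within the scatter); both steps are floors, so their true size may be larger, but what can be read so far stays within the scatter. Placing a carbonyl between the amine nitrogen and the 2-fluorophenyl group leaves the read-out level, with a 1.0-fold lower number from compound 1 to compound 4 (0.01 log units; within the scatter), and the two remaining compounds give no number of their own: the limit of > 20000 nM in this assay, at which 2 of the 4 values shown sit.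

The real size of the steps to compound 2 and compound 3 stays unread, and the step between those two compounds cannot be read at all. On these data alone, how an amine, a carboxylic acid or a longer chain on the carbonyl carbon would read in this assay also stays open.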